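Swapping the iodoacetamide tail on a triphosphate chain

This account rests on a few compounds, and the source may have more. Where it says the series, first, only, none or still open, it means among the compounds named here.

Compound 1 `O=C(CI)NCCCCCCCNc1ncnc2c1ncn2[C@@H]1O[C@H](COP(=O)(O)OP(=O)(O)OP(=O)(O)O)[C@@H](O)[C@H]1O` and compound 2 `O=C(CI)NCCCCCC(=O)NCCCCNc1ncnc2c1ncn2[C@@H]1O[C@H](COP(=O)(O)OP(=O)(O)OP(=O)(O)O)[C@@H](O)[C@H]1O` share a core carrying a triphosphate and a long chain. In an assay on isolated protein for inhibition of hexokinase-3 (Rattus norvegicus), with a stated time of 6 h, tested at 10 mM (on this read-out lower numbers stand for less inhibition and higher numbers for more inhibition at the one concentration tested (going by the name of the read-out)), compound 1 gives 20%, the higher of the two numbers; compound 2 gives 0%, a gap beyond the scatter. Compound 3 `CC(=O)NCCCCCCCCNc1ncnc2c1ncn2[C@@H]1O[C@H](COP(=O)(O)OP(=O)(O)OP(=O)(O)O)[C@@H](O)[C@H]1O` has not been measured. It differs from compound 1 by acetamidomethyl in place of ((iodomethyl)carbonyl)amino on a saturated chain carbon, seven bonds along the chain from a nitrogen on an aromatic ring. Within the data shown here, no measured pair shows this change, so its size is a guess; a moderate drop beyond the scatter is expected. For compound 3 the expected step of a number 15 percentage points lower from compound 1 to compound 3 (beyond the scatter) leads to an estimated 5%, likely between 0% and 20%.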

Compound 3, a percentage reported as inhibition, at one concentration (the size of the read-out at that concentration, not a potency): 0%
For compound 3 the middle estimate is 5 percentage points above the measured one; the range from low to high includes it.
By their numbers in this assay, from the lowest: compounds 2 and 3 (each within the scatter of the next); then compound 1.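

In this assay, replacing ((iodomethyl)carbonyl)amino with acetamidomethyl on a saturated chain carbon, seven bonds along the chain from a nitrogen on an aromatic ring, gives a step of a number 20 percentage points lower from compound 1 to compound 3 (beyond the scatter). Among these compounds, this is the first direct reading of this change, and it shows that the end of the chain affects this read-out. No measurement shown explains the step.

The change removes iodine and adds carbon at once, and the compounds shown do not separate the two. From the compounds shown here alone, whether a chloroacetamide or an amine at this chain end would restore inhibition remains open.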